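The compounds below may be only part of what the source reports. "The series", "measured", "known", "first", "only" and "open" are said of these compounds alone.

The series shares a spirocyclic core and is followed in an assay on HEK293 cells for displacement of a labelled ligand from NPC1-like intracellular cholesterol transporter 1 (Homo sapiens); on this read-out higher numbers stand for weaker inhibition and lower numbers for stronger inhibition. Compound 1, `CC(C)(C)OC(=O)NCC1CCCN(C(=O)CN2CN(c3ccccc3)C3(CCN(C(=O)c4ccc(C5CCCCC5)cc4)CC3)C2=O)C1`, gives 3800 nM in this assay. Compound 3, `NCCNC(=O)CN1CN(c2ccccc2)C2(CCN(C(=O)c3ccc(C4CCCCC4)cc3)CC2)C1=O`, gives 3800 nM. Compound 2, `CC1(C)CC(OC(=O)CN2CN(c3ccccc3)C3(CCN(C(=O)c4ccc(C(C)(C)C)cc4)CC3)C2=O)CC(C)(C)N1`, gives 1300 nM and so stands at the lowest number of the three, the others lying beyond the usual scatter above it; compound 1 and compound 3 sit at the same value as each other.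

The step considered here leads from compound 2 to compound 4, `CC(C)(C)c1ccc(C(=O)N2CCC3(CC2)C(=O)N(CC(=O)NCCCCCO)CN3c2ccccc2)cc1`, which has not yet been measured. The change is (5-hydroxypentyl)amino in place of (2,2,6,6-tetramethylpiperidin-4-yl)oxy on a carbonyl carbon. The (2,2,6,6-tetramethylpiperidin-4-yl)oxy group leaves and (5-hydroxypentyl)amino enters on the carbonyl carbon whose other neighbour is a saturated chain carbon; the rest of compound 2 is kept.

No comparable single change has been measured in this set. Compound 4 is expected to lie somewhat above compound 2, by about a 1.9-fold higher number from compound 2 to compound 4 (0.28 log units; within the scatter), a step that may not clear the scatter. The estimate for compound 4 is 2500 nM, with a range from 1000 nM to 6500 nM.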

Compound 4, half-maximal inhibitory concentration: 9400 nM
The estimate for compound 4 lay 3.8-fold (0.58 log units) below the measured number; measured number outside the range, above it.
By their numbers in this assay, from the lowest: compound 2; then compounds 1 and 3 (each within the scatter of the next); then compound 4.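

In this assay, the group on this carbonyl carbon proves to matter: with the rest of compound 2 kept, exchanging (2,2,6,6-tetramethylpiperidin-4-yl)oxy for (5-hydroxypentyl)amino gives a 7.2-fold higher number from compound 2 to compound 4 (0.86 log units; beyond the scatter). The exchange alters several features at once, as a six-membered non-aromatic ring with 11 heavy atoms gives way to an open chain with 7, and the atom joined to the carbonyl carbon changes from oxygen to nitrogen, so this single step cannot separate their contributions. No measurement available here explains the rise in the number.

Going by these compounds, it remains open whether the ring or the linking atom counts for more, which a (2,2,6,6-tetramethylpiperidin-4-yl)amino group on the same carbonyl carbon would begin to address. The role of the terminal hydroxyl is equally unsettled, and a pentylamino chain or one ending in a primary amine or a carboxylic acid would bear on it.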